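Furan for Pyridine on a Hydroxyphenyl Pyridine Core

A few compounds are considered here, and "the series" means these few. Any claim that something is new, unique, unknown or untested is made for them only; others in the source may bear on it.

Measured compounds:
- compound 1, `Oc1cccc(-c2cc(-c3ccc(Cl)cc3)nc(-c3ccccn3)c2)c1`: 13500 nM
- compound 2, `Oc1cccc(-c2cc(-c3ccc(Cl)cc3)nc(-c3ccco3)c2)c1`: 10200 nM
- compound 3, `Oc1ccc(-c2cc(-c3ccc(Cl)cc3)nc(-c3ccccn3)c2)cc1`: 21300 nM

All three were tested in a functional assay on HCT-15 cells (Homo sapiens) for cytotoxicity, read by CCK-8 assay and cell counting, with a stated time of 2 days; a higher number here means a weaker inhibitor, a lower number a stronger inhibitor. Compound 1 and compound 3 share the same atoms joined differently; the difference between their cores is 4-hydroxyphenyl in place of 3-hydroxyphenyl on an aromatic carbon, and the step between them, a 1.6-fold higher number from compound 1 to compound 3 (0.20 log units; within the scatter), is small. Compound 2 differs from compound 1 by the change (furan-2-yl in place of pyridin-2-yl on an aromatic carbon), and the resulting step, a 1.3-fold lower number from compound 1 to compound 2 (0.12 log units; within the scatter), is also within the scatter. Compound 3 has the highest number of the three, but only its gap to compound 2 is beyond the scatter.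

Compound 4, `Oc1ccc(-c2cc(-c3ccc(Cl)cc3)nc(-c3ccco3)c2)cc1`, is not yet measured. It differs from compound 3 by furan-2-yl in place of pyridin-2-yl on an aromatic carbon, the same kind of change as from compound 1 to compound 2, though the surroundings differ: in compound 3 the place is meta to a 4-hydroxyphenyl group, whereas in compound 1 it is meta to a 3-hydroxyphenyl group.

For the measured compounds named here, because the only example of this change gave a 1.3-fold lower number from compound 1 to compound 2 (0.12 log units; within the scatter), compound 4 is expected to sit close to compound 3, with an estimated step of a 1.3-fold lower number from compound 3 to compound 4 (0.10 log units; within the scatter). On that basis the expected value for compound 4 in this assay is 17000 nM, likely between 8000 nM and 36000 nM.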

Compound 4, half-maximal inhibitory concentration: 7020 nM
The estimate for compound 4 lay 2.4-fold (0.38 log units) above the measured number, and the stated range ends above it.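

In this assay, furan-2-yl in place of pyridin-2-yl gives a 3.0-fold lower number from compound 3 to compound 4 (0.48 log units; beyond the scatter), which looks larger than the same change made with a 3-hydroxyphenyl group on the core, yet the two steps cannot be told apart: the same change on two cores in this assay, a 1.3-fold lower number (0.12 log units; within the scatter) from compound 1 to compound 2 and a 3.0-fold lower number (0.48 log units; beyond the scatter) from compound 3 to compound 4, 2.3-fold (0.36 log units) apart, within the scatter of two such steps. Moving the hydroxyl group, with furan-2-yl held in place, gives a 1.5-fold lower number from compound 2 to compound 4 (0.16 log units; within the scatter), and this change also carries across without a clear difference: the same change on two cores in this assay, a 1.6-fold higher number (0.20 log units; within the scatter) from compound 1 to compound 3 and a 1.5-fold lower number (0.16 log units; within the scatter) from compound 2 to compound 4, 2.3-fold (0.36 log units) apart, within the scatter of two such steps. So, in these four compounds, each change behaves alike on both cores within the scatter, but two pairs cannot fix the true size of either step, and they cannot show that the changes would carry over to cores not shown here.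

The compounds shown leave open whether other groups in the place held by furan-2-yl, such as thiophene-2-yl or a simple amine, would give a similar number. They also leave open what would follow if a methoxy group replaced the hydroxyl group or a plain phenyl group replaced the 4-chlorophenyl group, and whether these steps hold in cells other than HCT-15.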